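Swapping an iodinated ring for thiophene

The source may report more compounds than this note shows. Statements on the series, on what has been measured and on what is new or still open speak of the compounds shown alone.

Compound 1 `Oc1ccc(CN(Cc2cccc(C(F)(F)F)c2)Cc2ccc(O)c3ncccc23)c2cccnc12`: 65 nM
Compound 2 `Oc1ccc(CN(Cc2cccc(I)c2)Cc2ccc(O)c3ncccc23)c2cccnc12`: 5600 nM

In a functional assay on U-373MG ATCC cells (Homo sapiens) for cytotoxicity, read by MTT assay (a lower number here means a stronger inhibitor, a higher number a weaker inhibitor), compound 2 has the higher of the two numbers, 5600 nM, which makes it the weaker inhibitor of the pair. Compound 3 `Oc1ccc(CN(Cc2cccs2)Cc2ccc(O)c3ncccc23)c2cccnc12` keeps the shared core but carries thiophen-2-yl in place of 3-iodophenyl on a saturated chain carbon bound to an amine nitrogen. Among the measured compounds shown here, only one measured step bears on this change, an 86-fold higher number from compound 1 to compound 2 (1.94 log units; beyond the scatter). It is large, and it came from altering a single group on the same ring that leaves here. Changes to this ring can therefore move the number a long way, but no measured compound carries a thiophene, so the size of the next step is uncertain. A moderate drop in this assay seems likely, and compound 3 is expected to remain a weaker inhibitor than compound 1, which gives 65 nM. The expected change is a 3.7-fold lower number from compound 2 to compound 3 (0.57 log units; beyond the scatter). For compound 3 the estimated value is 1500 nM, with an expected range of 200 nM to 9000 nM.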

Compound 3, half-maximal inhibitory concentration: 85 nM
For compound 3 the middle estimate is 18-fold (1.25 log units) above the measured one; measured number below the stated range.
By their numbers in this assay, from the lowest: compounds 1 and 3 (each within the scatter of the next); then compound 2.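

In this assay the swap of 3-iodophenyl for thiophen-2-yl gives a 66-fold lower number from compound 2 to compound 3 (1.82 log units; beyond the scatter) and shows that this position accepts a five-membered aromatic ring with one sulfur atom, and that replacing the whole ring can also produce a large step. Against the trifluoromethyl compound, the swap gives a 1.3-fold higher number from compound 1 to compound 3 (0.12 log units; within the scatter) and stays within the scatter, so thiophen-2-yl and 3-(trifluoromethyl)phenyl cannot be told apart here, and compound 2 alone sits apart from the other two. Nothing available explains why the 3-iodophenyl compound differs from the other two.

The compounds shown leave open whether the sulfur atom matters, which a furan-2-yl or unsubstituted phenyl ring at this place could test. They also leave open how a non-aromatic ring such as cyclohexyl would compare.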